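The compounds below may be only part of what the source reports. "The series", "measured", "known", "first", "only" and "open" are said of these compounds alone.

Working notes on the series. Compound 1 `CNC(=O)N1CCCc2ccc(NC(=O)c3ccc(-c4ccccc4)cc3)cc21` carries an unsubstituted phenyl on the benzamide and in a functional assay on MV4-11 cells (Homo sapiens) for antiproliferative activity, with a stated time of 6 days, tested at 6.25 uM (on this read-out lower numbers stand for a weaker effect and higher numbers for a stronger effect at the one concentration tested), compound 1 gives 74.3%, the highest of the three numbers in hand. Compound 3 `CNC(=O)N1CCCc2ccc(NC(=O)c3ccccc3-c3ccccc3)cc21`, with the phenyl moved to a different carbon of the benzamide, gives 60.4% in this assay, a number that sits beyond the scatter below compound 1. Compound 2 `CNC(=O)N1CCCc2ccc(NC(=O)c3cccc(-c4ccccc4)c3)cc21`, with the phenyl at the third possible carbon, gives 1.39% in this assay, far below the other two. No two of these three differ in a single place, so the three numbers only show that compound 1 is the strongest of the set and that the placement of the second ring matters.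

Compound 4 `CNC(=O)N1CCCc2ccc(NC(=O)c3ccc(-c4cn[nH]c4)cc3)cc21` keeps the core of compound 1 and differs by 1H-pyrazol-4-yl in place of phenyl on an aromatic carbon, on the same aromatic carbon, para to a large group. Nothing measured in the series speaks to a five-membered ring with two hetero atoms in this spot, so the expectation leans on compound 1 alone, with a wide range. The step from compound 1 to compound 4 in this assay is expected to be a modest loss, a number 16.3 percentage points lower from compound 1 to compound 4 (beyond the scatter), possibly within the scatter. Compound 4 is estimated at 58%, with a range from 22% to 85%.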

Compound 4, a percentage reported as inhibition, at one concentration (the size of the read-out at that concentration, not a potency): 98.3%
Compound 4: the middle estimate sits 40.3 percentage points below what was measured; measured number outside the range, above it.
By their numbers in this assay, from the lowest: compound 2; then compound 3; then compound 1; then compound 4.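

In this assay, 1H-pyrazol-4-yl in place of phenyl on the aromatic carbon para to a large group gives a number 24 percentage points higher from compound 1 to compound 4 (beyond the scatter) and so shows that this position does not depend on a six-membered aromatic ring of carbon only. A five-membered aromatic ring with 2 hetero atoms, bearing 1 hydrogen-bond donor and 1 hydrogen-bond acceptor where phenyl has none, is tolerated here and raises the read-out. Nothing in hand accounts for this rise, which rests on a single pair of compounds.

Still open, from the compounds shown here alone, is whether the ring hydrogen on nitrogen matters, which 1-methyl-1H-pyrazol-4-yl, a pyridinyl ring or an aminomethyl group on the same carbon would help to separate. Also open, going by these compounds, is how 1H-pyrazol-4-yl behaves on the benzamide carbons carrying phenyl in compound 2 and compound 3.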